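The compounds below may be only part of what the source reports. "The series", "measured", "known", "first", "only" and "open" are said of these compounds alone.

Compound 1 `Cc1cccc(NS(=O)(=O)c2ccc(N3CCNC3=O)cc2)c1`, compound 2 `O=C1NCCN1c1ccc(S(=O)(=O)Nc2cccc(Br)c2)cc1` and compound 3 `COc1cc(NS(=O)(=O)c2ccc(N3CCNC3=O)cc2)cc(OC)c1` share one core and differ only in the groups on a single aromatic ring. In a functional assay on MDA-MB-231 cells (Homo sapiens) for antiproliferative activity, read by sulforhodamine B assay, with a stated time of 48 h (on this read-out lower numbers stand for stronger inhibition and higher numbers for weaker inhibition), compound 1 gives 1270 nM, compound 2 gives 290 nM and compound 3 gives 340 nM. Compound 3 therefore stands level with compound 2, within the scatter, and clearly lower than compound 1, beyond the scatter.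

Compound 4 `COc1cccc(NS(=O)(=O)c2ccc(N3CCNC3=O)cc2)c1` takes one methoxy away from compound 3: hydrogen in place of methoxy on an aromatic carbon. This puts hydrogen in place of methoxy on an aromatic carbon, at a place meta to a large group and meta to a methoxy group, so the other methoxy stays.

Going by the values given here, no measured pair shows this exact change. The nearest guide is a 4.4-fold lower number from compound 1 to compound 2 (0.64 log units; beyond the scatter), a modest step with bromo in place of methyl on an aromatic carbon. It shows that one group on this ring can move the number beyond the scatter, but in which direction depends on the group. Compound 1 and compound 2 each carry one group on this ring, and they lie on either side of the expected value.

In this assay the expected change is a 1.8-fold higher number from compound 3 to compound 4 (0.25 log units; within the scatter), a small rise in the number that may not clear the scatter. For compound 4 the estimated value is 600 nM, with an expected range from 220 nM to 1500 nM.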

Compound 4, half-maximal inhibitory concentration: 730 nM
Compound 4: the middle estimate sits 1.2-fold (0.09 log units) below what was measured; the range from low to high includes it.
By their numbers in this assay, from the lowest: compounds 2 and 3 (each within the scatter of the next); then compounds 4 and 1 (each within the scatter of the next).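

In this assay, going by these compounds alone, taking one methoxy away gives a 2.1-fold higher number from compound 3 to compound 4 (0.33 log units; beyond the scatter), so at this place, meta to a large group and meta to a methoxy group, the extra methoxy moves the number beyond the scatter, which no earlier pair could show. Among the compounds with a single group on this ring, methoxy in place of bromo gives a 2.5-fold higher number from compound 2 to compound 4 (0.40 log units; beyond the scatter) and lies beyond the scatter, while methoxy in place of methyl gives a 1.7-fold lower number from compound 1 to compound 4 (0.24 log units; within the scatter) and stays within it, so a lone methoxy can be told apart from bromo but not from methyl. Nothing available here explains why the number shifts with these changes.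

The compounds shown leave open what the ring would give with no group on it at all, which would set a baseline for each single group. They also leave open whether the rise seen on losing a methoxy belongs to methoxy itself, or whether an amine, a carboxylic acid or a longer chain such as ethoxy at the same place would hold the number as low.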